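The source may hold more compounds than are shown below. What is called first, only, known or untested is meant among the compounds shown, and "the series" means these compounds.

Of the compounds shown here, three sharing one core have been tested in a functional assay on MGC-803 cells (Homo sapiens) for inhibition, read by sulforhodamine B assay; on this read-out higher numbers stand for weaker inhibition and lower numbers for stronger inhibition. Compound 1 `CCCc1ccc(NC2=CC(=O)c3nc4n(c3C2=O)[C@H]2OC[C@@H](O)[C@H]2OC4)cc1` gives 1560 nM, compound 2 `O=C1C=C(Nc2cccc(F)c2)C(=O)c2c1nc1n2[C@H]2OC[C@@H](O)[C@H]2OC1` gives 2180 nM, and compound 3 `CCOc1ccccc1NC1=CC(=O)c2nc3n(c2C1=O)[C@H]1OC[C@@H](O)[C@H]1OC3` gives 2450 nM. Compound 2 thus holds the second highest of the three numbers, nearest to compound 3 and furthest from compound 1, yet all three sit within the usual scatter of one another. Compound 4 `O=C1C=C(N2CCCCC2)C(=O)c2c1nc1n2[C@H]2OC[C@@H](O)[C@H]2OC1` differs from compound 2 in one place: piperidin-1-yl in place of (3-fluorophenyl)amino on a double-bonded ring carbon. The measured steps, a 1.4-fold higher number from compound 1 to compound 2 (0.15 log units; within the scatter), a 1.6-fold higher number from compound 1 to compound 3 (0.20 log units; within the scatter) and a 1.1-fold higher number from compound 2 to compound 3 (0.05 log units; within the scatter), each exchange one aromatic ring for another on the amine nitrogen and none exceeds the scatter; none removes the aromatic ring or the hydrogen-bond donor, so they offer no direct guide. A modest rise in the number, toward weaker inhibition, is expected but uncertain: a 2.1-fold higher number from compound 2 to compound 4 (0.31 log units; beyond the scatter). Compound 4 is estimated at 4500 nM, within 1500 nM to 15000 nM.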

Compound 4, half-maximal inhibitory concentration: > 8000 nM
Compound 4 gave a limit, no number (the forecaster's own chance of this, stated with the estimate: 10%); middle value at least 1.7-fold (0.24 log units) from the limit.
By their numbers in this assay, from the lowest: compounds 1, 2 and 3 (each within the scatter of the next). At a limit, above all of these: compound 4.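

The steps among compounds 1, 2 and 3 only exchanged one aromatic ring for another on the amine nitrogen. Among these compounds, replacing the whole (3-fluorophenyl)amino group with piperidin-1-yl, which removes both the aromatic ring and the hydrogen-bond donor, gives the only step beyond the scatter in this assay, toward weaker inhibition: an at least 3.6-fold higher number from compound 2 to compound 4 (0.56 log units; beyond the scatter). Compound 4 reads only as a limit, not as a number: the limit of > 8000 nM in this assay, at which 1 of the 4 values shown sits.

Ring and donor change together here, so the compounds shown cannot tell which one matters. Cyclohexylamino, which keeps the amine hydrogen on a non-aromatic ring, would separate the two.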